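Aryl change from compound 2 to compound 3

A few compounds are considered here, and "the series" means these few. Any claim that something is new, unique, unknown or untested is made for them only; others in the source may bear on it.

In a functional assay on MCF7 cells (Homo sapiens) for antiproliferative activity, read by MTT assay, with a stated time of 72 h (a higher number here means a weaker inhibitor, a lower number a stronger inhibitor), compound 1 `O=C(N/N=C/c1cccc(Br)c1)Nc1ccc(Oc2ccnc3[nH]ccc23)c(F)c1` gives 49 nM and compound 2 `O=C(N/N=C/c1ccc(Cl)c(Cl)c1)Nc1ccc(Oc2ccnc3[nH]ccc23)c(F)c1` gives 998 nM as the higher of the two numbers. Among the compounds with values here, the only measured step is large: a 20-fold higher number from compound 1 to compound 2 (1.31 log units; beyond the scatter) shows that this assay can respond strongly to the group on this carbon. Compound 3 `O=C(N/N=C/c1ccc(F)cc1Cl)Nc1ccc(Oc2ccnc3[nH]ccc23)c(F)c1` keeps the shared core and differs as follows: 2-chloro-4-fluorophenyl in place of 3,4-dichlorophenyl on a carbon with a double bond to nitrogen with 2-chloro-4-fluorophenyl in place of 3,4-dichlorophenyl on a carbon with a double bond to nitrogen. Within the data shown here, no measured step covers this exact change. With compound 1 at 49 nM as evidence that much lower numbers occur in the series, a modest move towards a lower number is expected, though the direction is uncertain. The expected change is a 2.5-fold lower number from compound 2 to compound 3 (0.40 log units; beyond the scatter) and should be smaller than the measured step. For compound 3 the estimate is 400 nM with 90 nM to 1800 nM as the expected range.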

Compound 3, half-maximal inhibitory concentration: 7610 nM
The estimate for compound 3 lay 19-fold (1.28 log units) below the measured number, outside the stated range (above it).
By their numbers in this assay, from the lowest: compound 1; then compound 2; then compound 3.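

In this assay, the step of a 7.6-fold higher number from compound 2 to compound 3 (0.88 log units; beyond the scatter) shows that replacing 3,4-dichlorophenyl with 2-chloro-4-fluorophenyl on a carbon with a double bond to nitrogen can raise the number substantially, even though both groups have the same heavy-atom count and neither has hydrogen-bond donors or acceptors. The wider step a 160-fold higher number from compound 1 to compound 3 (2.19 log units; beyond the scatter) extends the range seen at this position and places compound 3, with 2-chloro-4-fluorophenyl, as the weakest of the three compounds. No evidence available here accounts for these differences.

The compounds shown do not separate the change of halogen from the change in substitution pattern between 3,4-dichlorophenyl and 2-chloro-4-fluorophenyl. On these data alone, how an amine or a carboxylic acid on this phenyl ring would affect the number remains open.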